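Carbonyl aryl variation on the shared core

This account rests on a few compounds, and the source may have more. Where it says the series, first, only, none or still open, it means among the compounds named here.

Compound 1 `COc1ccc(-c2cc3ccccc3nc2/C=C/C(=O)c2ccc(OC)c(OC)c2)cc1`, compound 2 `COc1ccc(-c2cc3ccccc3nc2/C=C/C(=O)c2ccc(N)cc2)cc1` and compound 3 `COc1ccc(-c2cc3ccccc3nc2/C=C/C(=O)c2ccc(Br)s2)cc1` share one core and differ only in the group on the carbonyl carbon. In a functional assay on MDA-MB-231 cells (Homo sapiens) for antiproliferative activity, read by XTT assay, with a stated time of 72 h (on this read-out higher numbers stand for weaker inhibition and lower numbers for stronger inhibition), compound 1 gives 4790 nM. In this assay compound 2 gives 7510 nM, and a 1.6-fold higher number from compound 1 to compound 2 (0.20 log units; within the scatter). For compound 3 this assay reports only a limit, < 100 nM, so compound 3 stands at the limit of < 100 nM in this assay, at which 1 of the 3 values shown sits, rather than at a number. Even so, an at least 47-fold lower number from compound 1 to compound 3 (1.68 log units; beyond the scatter) and an at least 75-fold lower number from compound 2 to compound 3 (1.87 log units; beyond the scatter), both large steps.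

Compound 4 `COc1ccc(-c2cc3ccccc3nc2/C=C/C(=O)c2ccsc2)cc1` is not yet measured in this assay. The change from compound 3 is thiophen-3-yl in place of 5-bromothiophen-2-yl on a carbonyl carbon. For the measured compounds named here, the measured steps that bear on it, an at least 47-fold lower number from compound 1 to compound 3 (1.68 log units; beyond the scatter) and an at least 75-fold lower number from compound 2 to compound 3 (1.87 log units; beyond the scatter), both reach compound 3 from a substituted phenyl on the carbonyl carbon, whereas compound 4 keeps a five-membered ring with one hetero atom; no measured step separates the bromine from the ring type or from the point of attachment. The expectation is therefore a moderate loss, an at least 4.0-fold higher number from compound 3 to compound 4 (0.60 log units; beyond the scatter), with wide uncertainty since compound 3 is known only as a limit. Compound 4 is expected to give about 400 nM in this assay, somewhere between 80 nM and 2000 nM.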

Compound 4, half-maximal inhibitory concentration: 1060 nM
Compound 4: the middle estimate sits 2.7-fold (0.42 log units) below what was measured, within the range that was stated.
By their numbers in this assay, from the lowest: compound 4; then compounds 1 and 2 (each within the scatter of the next). At a limit, below all of these: compound 3.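

Keeping a five-membered aromatic ring with 1 hetero atom on the carbonyl carbon does not by itself hold the activity of the brominated compound: in this assay, the change to thiophen-3-yl gives an at least 10-fold higher number from compound 3 to compound 4 (1.02 log units; beyond the scatter). The same ring still stands apart from both substituted phenyl groups, with a 7.1-fold lower number from compound 2 to compound 4 (0.85 log units; beyond the scatter) and a 4.5-fold lower number from compound 1 to compound 4 (0.66 log units; beyond the scatter), so among these compounds the thiophene ring alone accounts for part of the separation from the phenyl compounds, and the rest goes with the change from 5-bromothiophen-2-yl to thiophen-3-yl. Compound 3 is held only as a limit, so the full size of that second part stays unfixed: the limit of < 100 nM in this assay, at which 1 of the 4 values shown sits.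

The bromine and the point of attachment change together from compound 3 to compound 4, and the compounds shown do not tell which of the two carries the step. Open as well is where an unbrominated thiophen-2-yl group, or a thiophen-2-yl group with chlorine in place of the bromine, would stand on the same carbonyl carbon.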